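Swapping acetyl for dimethylamino on a cytotoxic pyrazole series

The compounds below may be only part of what the source reports. "The series", "measured", "known", "first", "only" and "open" are said of these compounds alone.

Measured so far:
- compound 1 `COc1cc(C)cc(-c2c(-c3ccnc(-c4ccc(C(C)=O)cc4)c3)cnn2CC#N)c1`: -10%
- compound 2 `COc1cc(C)cc(-c2nn(CC#N)cc2-c2ccnc(-c3ccc(N(C)C)cc3)c2)c1`: -64%

Of the compounds shown here, two have been tested in a functional assay on NCI-H522 cells (Homo sapiens) for cytotoxicity, read by sulforhodamine B assay, with a stated time of 48 h, tested at 10 uM; a higher number here means a weaker effect of the compound at the concentration tested, a lower number a stronger effect. Compound 1 gives -10%, the highest of the two numbers, so it shows the weaker effect. Compound 2 gives -64%, a value that lies well beyond the usual scatter below that of compound 1.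

The next compound to be measured is compound 3 `COc1cc(C)cc(-c2c(-c3ccnc(-c4ccc(N(C)C)cc4)c3)cnn2CC#N)c1`. It differs from compound 1 in one place: dimethylamino in place of acetyl on an aromatic carbon. The acetyl group sitting on the outer benzene ring is replaced by a dimethylamino group, with everything else in the shared core of compound 1 kept unchanged.

Within the data shown here, no measured pair shows this exact change, so no step can be read off directly. On the two values seen, a dimethylamino-bearing compound gave the lower number, so the estimated step of a number 35 percentage points lower from compound 1 to compound 3 (beyond the scatter) is expected to go downward, beyond the scatter. Compound 3 is therefore expected to give about -45%, within a range from -75% to -15%.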

Compound 3, a percentage reported as activity, at one concentration (the size of the read-out at that concentration, not a potency): -52%
Compound 3: middle estimate off by 7 percentage points, on the high side, within the range that was stated.
By their numbers in this assay, from the lowest: compound 2; then compound 3; then compound 1.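

In this assay, replacing 4-acetylphenyl with 4-(dimethylamino)phenyl gives a number 42 percentage points lower from compound 1 to compound 3 (beyond the scatter), so this single change on an aromatic carbon, para to a large group, produces a stronger effect at the concentration tested. This pair isolates the change, which the earlier comparison could not do because compound 1 and compound 2 differ in more than one place. The two groups match in size and acceptor count, at 3 heavy atoms and 1 hydrogen-bond acceptor each, so those counts alone do not separate them, and the data shown offer no measurement that explains the shift.

From the compounds shown here alone, what remains open is whether the nitrogen, its two methyl groups or the loss of the carbonyl matters most, which a simple amine, a morpholine ring or a methoxy group at the same place could help to separate. A carboxylic acid at this place would extend the comparison in a different direction, and a single cell line leaves open whether the step also appears in other cells.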